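The source may report more compounds than this note shows. Statements on the series, on what has been measured and on what is new or still open speak of the compounds shown alone.

Three compounds of the series have numbers in a functional assay (lung) for inhibition, with Cavia porcellus as the target; a lower number here means a stronger inhibitor, a higher number a weaker inhibitor. Compound 1 `O=C(O)CCC(Cc1cccc(OCc2ccc3ccccc3n2)c1)c1ccccc1` gives 56 nM. Compound 3 `CCCC(CCC(=O)O)Cc1cccc(OCc2ccc3ccccc3n2)c1` gives 70 nM. Compound 2 `CCCC(CCc1nnn[nH]1)Cc1ccc(OCc2ccc3ccccc3n2)cc1` gives 32 nM; its gap to compound 1 lies within the scatter, and only its gap to compound 3 lies beyond it. Compound 3 and compound 1 differ in one place, (phenyl in place of propyl on a saturated chain carbon bound to two saturated chain carbons), and that step is a 1.3-fold lower number from compound 3 to compound 1 (0.10 log units; within the scatter). How the core of compound 2 differs from the core of compound 3 is not broken down here.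

Compound 4 `c1ccc(C(CCc2nnn[nH]2)Cc2ccc(OCc3ccc4ccccc4n3)cc2)cc1` is not yet measured. It stands to compound 2 as compound 1 stands to compound 3: phenyl in place of propyl on a saturated chain carbon bound to two saturated chain carbons. The place is the same in both pairs word for word, so this is the same change made a second time. The expected step in this assay is a 1.3-fold lower number from compound 2 to compound 4 (0.11 log units; within the scatter), resting on a 1.3-fold lower number from compound 3 to compound 1 (0.10 log units; within the scatter) and on compound 2 at 32 nM, since that earlier step stayed within the scatter. For compound 4 the expected value in this assay is 25 nM, with a likely range from 12 nM to 55 nM.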

Compound 4, half-maximal inhibitory concentration: 14 nM
Compound 4: the middle estimate sits 1.8-fold (0.25 log units) above what was measured; the measured number falls inside the stated range.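

In this assay, phenyl in place of propyl on a saturated chain carbon bound to two saturated chain carbons gives a 2.3-fold lower number from compound 2 to compound 4 (0.36 log units; beyond the scatter). Set beside the same change on the other core, this step does not differ from the earlier one by more than the scatter of two such steps allows: the same change on two cores in this assay, a 1.3-fold lower number (0.10 log units; within the scatter) from compound 3 to compound 1 and a 2.3-fold lower number (0.36 log units; beyond the scatter) from compound 2 to compound 4, 1.8-fold (0.26 log units) apart, within the scatter of two such steps. The change therefore carries from one core to the other with no measurable difference in size, even though only the newer step lies beyond the scatter, but two pairs neither fix a common size for it nor show that it would hold on any further core.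

The compounds shown leave open how a cyclohexyl group, a benzyl group or a longer chain would behave at this same place. From the compounds shown here alone, it also remains open whether the step would hold on a core carrying an amide at the end of the chain, in this assay or in any other assay.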